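Swapping a Benzyl Arm for Cyclopropylmethyl on a Shared Core

This account rests on a few compounds, and the source may have more. Where it says the series, first, only, none or still open, it means among the compounds named here.

Compound 1, `COc1cc2nc(C3CCC3)nc(N3CCN(c4ccccc4C)CC3)c2cc1OC`: in an in vitro assay on U2OS cells for agonist activity at neurotensin receptor type 2 (Homo sapiens), read by reporter gene assay and beta-arrestin recruitment (on this read-out higher numbers stand for an effect only at larger amounts of compound and lower numbers for an effect already at smaller amounts), compound 1 gives > 80000 nM, which is a limit of the assay rather than a number.
Compound 2, `COc1cc2nc(C3CCC3)nc(N3CCN(c4ccccn4)CC3)c2cc1OC`: in this assay compound 2 gives > 80000 nM, again a limit.
Compound 3, `COc1cc2nc(Cc3ccccc3)nc(N3CCN(c4ccccc4OC)CC3)c2cc1OC`: in this assay compound 3 gives > 80000 nM, also a limit.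

Compound 3 therefore stands at the limit of > 80000 nM in this assay, at which 3 of the 3 values shown sit, and no number places it anywhere within that range. Among the measured compounds shown here, the only measured step, a step that the two limits leave unreadable from compound 1 to compound 2, runs between two limits and so yields no readable size; it also concerns a different part of the core and does not bear on the change at hand.

Compound 4, `COc1cc2nc(CC3CC3)nc(N3CCN(c4ccccc4OC)CC3)c2cc1OC`, differs from compound 3 by cyclopropyl in place of phenyl on a saturated chain carbon bound to an aromatic carbon. For the measured compounds named here, no measured pair shows this change, so no size of step can be carried over from the data. With all three measured compounds sitting at the limit, the expectation for compound 4 in this assay is simply that it, too, reports a limit, meaning a step of a number no higher from compound 3 to compound 4 (the limit leaves the size open), none beyond the scatter as far as can be told. The estimate for compound 4 is 80000 nM, expected to fall between 20000 nM and 300000 nM.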

Compound 4, half-maximal effective concentration: > 80000 nM
Compound 4 gave a limit, no number (the forecaster's own chance of this, stated with the estimate: 85%); the middle value lies on the limit itself.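

In this assay compound 3 and compound 4 both give a limit and not a number, so the step between them cannot be read: the limit of > 80000 nM in this assay, at which 4 of the 4 values shown sit.

The compounds shown leave open whether swapping benzyl for cyclopropylmethyl changes the read-out at all, and none of them yet gives a number to compare.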